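The compounds below may be only part of what the source reports. "The series", "measured", "known", "first", "only" and "open" are said of these compounds alone.

Compound 1 `Cc1oc2c([C@H]3CCN(C)C[C@H]3O)c(O)cc(O)c2c(=O)c1C(O)c1c(Cl)cccc1Cl`: 24%
Compound 2 `CN1CC[C@H](c2c(O)cc(O)c3c(=O)cc(/C=C/c4cccc(Cl)c4)oc23)[C@H](O)C1`: 55%

Both compounds were tested in a functional assay on Caco-2 cells (Homo sapiens) for inhibition, read by MTT assay, with a stated time of 48 h, tested at 10 uM; on this read-out higher numbers stand for more inhibition of growth at the one concentration tested and lower numbers for less inhibition of growth. Of the two numbers, the higher belongs to compound 2, at 55%, while compound 1 gives 24%, and this gap lies beyond the usual scatter of such measurements. The two structures differ in more than one place, however, so the gap cannot be tied to any single structural change.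

The next compound to consider is compound 3 `CN1CC[C@H](c2c(O)cc(O)c3c(=O)cc(/C=C/c4ccccc4Cl)oc23)[C@H](O)C1`, which keeps the core of compound 2 and carries the same atoms, joined differently. The change is 2-chlorophenyl in place of 3-chlorophenyl on a double-bonded chain carbon bound to a double-bonded chain carbon: 2-chlorophenyl stands in place of 3-chlorophenyl on a double-bonded chain carbon bound to a double-bonded chain carbon.

Within the data shown here, no measured pair shows what a change of this kind does in this assay, so the starting point is compound 2 at 55%. No step beyond the scatter is expected, in either direction. The estimated result is a number 5 percentage points lower from compound 2 to compound 3 (within the scatter). Compound 3 is expected to give 50%, with an estimated range from 30% to 68%.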

Compound 3, percent growth inhibition at one concentration: 65%
For compound 3 the middle estimate is 15 percentage points below the measured one; low and high end bracket the measured number.
By their numbers in this assay, from the lowest: compound 1; then compounds 2 and 3 (each within the scatter of the next).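

Among these compounds, this is the first pair in the set that differs in one place only, so a single change can finally be read: 2-chlorophenyl in place of 3-chlorophenyl on a double-bonded chain carbon bound to a double-bonded chain carbon gives a number 10 percentage points higher from compound 2 to compound 3 (within the scatter) in this assay. The two groups have the same atoms and the same counts, so only the place of the chlorine on the ring has changed, and at this single concentration that move does not separate compound 2 from compound 3 beyond the usual scatter. Nothing else measured here helps to explain how either compound behaves in these cells.

As far as these compounds go, what the chlorine itself contributes remains open, since both compounds carry it; a plain phenyl, a 4-chlorophenyl or a 2-methoxyphenyl at the same place on the chain would test whether this part of the molecule matters at all. With one concentration per compound, it is also unknown whether compound 2 and compound 3 would still read alike across a range of concentrations.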